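This account rests on a few compounds, and the source may have more. Where it says the series, first, only, none or still open, it means among the compounds named here.

Among the measured compounds shown here, in a functional assay on SK-OV-3 cells (Homo sapiens) for inhibition, read by sulforhodamine B assay, with a stated time of 48 h (a lower number here means that less compound is tolerated, a higher number that more compound is tolerated), only two compounds have been read so far, and neither gives a number. Compound 1 `O=C(Nc1cccc(-n2cc(-c3ccncc3)c(-c3ccc(Cl)c(O)c3)n2)c1)Nc1cccc(C(F)(F)F)c1` gives > 32500 nM, which is a limit of the assay. Compound 2 `COc1cc(-c2nn(-c3cccc(NC(=O)c4cccc(C(F)(F)F)c4)c3)cc2-c2ccncc2)ccc1Cl` gives > 50000 nM, which is also a limit, and this limit is all that is known of where compound 2 stands. Compound 3 `COc1cc(-c2nn(-c3cccc(NC(=O)Nc4ccc(Cl)c(C(F)(F)F)c4)c3)cc2-c2ccncc2)ccc1Cl` differs from compound 2 in one place: on a carbonyl carbon, (4-chloro-3-(trifluoromethyl)phenyl)amino stands in place of 3-(trifluoromethyl)phenyl ((4-chloro-3-(trifluoromethyl)phenyl)amino in place of 3-(trifluoromethyl)phenyl on a carbonyl carbon). For the measured compounds named here, no measured pair shows what such a change does in this assay, so any expectation here is loose. A modest move towards a lower tolerated concentration is expected, although the reading may again be only a limit, and the estimated shift is an at least 1.4-fold lower number from compound 2 to compound 3 (0.15 log units; that floor lies within the scatter). For compound 3 the expected value is 35000 nM, with an estimated range from 10000 nM to 70000 nM.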

Compound 3, concentration lethal to 50% of the cells: > 32500 nM
Compound 3 gave a limit, no number (the forecaster's own chance of this, stated with the estimate: 55%); the middle value is on the limit's open side.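

Compound 2 and compound 3 both gave only limits, so the step between them cannot be read. The compounds shown leave open what (4-chloro-3-(trifluoromethyl)phenyl)amino in place of 3-(trifluoromethyl)phenyl does in this assay, and what actual value any of the three compounds would give.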